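This account rests on a few compounds, and the source may have more. Where it says the series, first, only, none or still open, it means among the compounds named here.

Compounds 1 and 2 share one core and differ only in the number of methoxy groups on the same ring: compound 1 `COc1ccc(-c2cc(/C=C/C(=O)c3ccc(N)cc3)[nH]n2)cc1` and compound 2 `COc1cc(-c2cc(/C=C/C(=O)c3ccc(N)cc3)[nH]n2)cc(OC)c1OC`. In a functional assay on K562 cells (Homo sapiens) for cytotoxicity, read by sulforhodamine B assay, with a stated time of 48 h, tested at 0.1 uM (on this read-out lower numbers stand for a stronger effect and higher numbers for a weaker effect at the one concentration tested), compound 1 gives 95%. In this assay compound 2 gives 94%, the lower of the two numbers, although the gap to compound 1 lies within the scatter. As far as these compounds go, compound 3 `COc1ccc(-c2cc(/C=C/C(=O)c3ccc(N)cc3)[nH]n2)cc1OC` is still untested; it differs from compound 2 by hydrogen in place of methoxy on an aromatic carbon, the methoxy leaving and a hydrogen entering on an aromatic carbon ortho to a methoxy group. Because compound 2 stands at 94% and compound 1 at 95%, no change beyond the scatter is expected. In this assay the expected step is no change at the digits printed from compound 2 to compound 3 (within the scatter). Compound 3 is estimated at 94%, expected between 84% and 100%.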

Compound 3, a percentage reported as activity, at one concentration (the size of the read-out at that concentration, not a potency): 98%
For compound 3 the middle estimate is 4 percentage points below the measured one; measured number inside the range.
By their numbers in this assay, from the lowest: compounds 2, 1 and 3 (each within the scatter of the next).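

In this assay, taking a methoxy group off this ring carbon gives a number 4 percentage points higher from compound 2 to compound 3 (within the scatter), and placing one on the same ring of compound 1 gives a number 3 percentage points higher from compound 1 to compound 3 (within the scatter). At the one concentration tested, this position therefore tolerates hydrogen or methoxy without any step leaving the scatter, whichever neighbouring compound is the starting point. No other measurement bears on these numbers. As far as these compounds go, it remains open whether a hydroxyl group or a dimethylamino group on this carbon would move the number beyond the scatter, and whether these methoxy changes would separate the compounds at a higher concentration.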